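The source may hold more compounds than are shown below. What is called first, only, known or untested is meant among the compounds shown, and "the series" means these compounds.

Compound 1 `O=C(O)CC/C=C\CO[C@H]1C(OCc2ccc(-c3ccc(CO)cc3)cc2)CC[C@@H]1N1CCCCCC1` is the starting point of this small series. In a functional assay for antagonist activity at thromboxane A2 receptor (Rattus norvegicus) (on this read-out lower numbers stand for tighter binding and higher numbers for weaker binding), compound 1 gives 20 nM. Compound 2 `CC(=O)NCc1ccccc1-c1ccc(COC2CC[C@H](N3CCCCCC3)[C@H]2OC/C=C\CCC(=O)O)cc1` carries a 2-(acetamidomethyl)phenyl group in place of the 4-(hydroxymethyl)phenyl group of compound 1, and in this assay compound 2 gives 126 nM. That makes compound 2 the higher of the two single numbers shown, with the step of a 6.3-fold higher number from compound 1 to compound 2 (0.80 log units; beyond the scatter). Compound 3 `O=C(O)CC/C=C\CO[C@H]1C(OCc2ccc(-c3ccccc3)cc2)CC[C@@H]1N1CCCCC1` has been measured more than once, and in this assay compound 3 gives 794 nM; 63.1 nM (2 entries); the spread among these entries, (the several entries of compound 3 in this assay, 794 nM; 63.1 nM (2 entries)), shows how far repeated measurements of this kind can drift apart.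

Compound 4 `CS(=O)(=O)Nc1cccc(-c2ccc(COC3CC[C@H](N4CCCCCC4)[C@H]3OC/C=C\CCC(=O)O)cc2)c1` differs from compound 2 in one place: 3-(methanesulfonamido)phenyl in place of 2-(acetamidomethyl)phenyl on an aromatic carbon. Within the data shown here, only one measured step involves the same position, the change from compound 1 to compound 2, which weakened binding by a 6.3-fold higher number from compound 1 to compound 2 (0.80 log units; beyond the scatter). That step removed a small hydroxymethyl-bearing ring and brought in an acetamidomethyl-bearing ring. Moving to a methanesulfonamido-bearing ring is another exchange of a polar group on that outer ring, so a step of modest size in either direction is plausible, and a return toward the number of compound 1 seems somewhat more likely than a further rise. The expected step is a 2.5-fold lower number from compound 2 to compound 4 (0.40 log units; beyond the scatter). Compound 4 is therefore estimated at 50 nM, within a range from 12 nM to 200 nM.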

Compound 4, dissociation constant: 50.1 nM
Estimate against measurement, compound 4: 1.0-fold (0.00 log units) below; measured number inside the range.
By their numbers in this assay, from the lowest: compound 1; then compound 4; then compound 2.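

In this assay, exchanging the 2-(acetamidomethyl)phenyl group for the 3-(methanesulfonamido)phenyl group gives a 2.5-fold lower number from compound 2 to compound 4 (0.40 log units; beyond the scatter), so this place on the aromatic ring, para to a large group, responds to a change between two groups with the same count of heavy atoms. The loss seen with the earlier exchange is only partly recovered, as the comparison with the 4-(hydroxymethyl)phenyl group shows a 2.5-fold higher number from compound 1 to compound 4 (0.40 log units; beyond the scatter), and among the three groups read at this place, compound 1 keeps the lowest number. All of these steps are modest and rest on few entries, and they need some caution because repeated entries for a single compound can lie far apart: the several entries of compound 3 in this assay, 794 nM; 63.1 nM (2 entries)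

The exchange from compound 2 to compound 4 alters both the group and where it sits on the phenyl ring, so the compounds shown cannot separate these two changes. From the compounds shown here alone, how an amine or a carboxylic acid on this phenyl ring would compare with the hydroxymethyl, acetamidomethyl and methanesulfonamido groups remains open.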